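The source may hold more compounds than are shown below. What is called first, only, known or untested is meant among the compounds shown, and "the series" means these compounds.

Going by the values given here, compound 1 `CC(C)OC1=C(C(=O)c2ccccc2)C(c2ccc(Br)cc2)N(CCCn2ccnc2)C1=O` is tested in a functional assay on A549 cells (Homo sapiens) for antiproliferative activity, read by MTT assay, with a stated time of 72 h (on this read-out higher numbers stand for weaker inhibition and lower numbers for stronger inhibition), where compound 1 gives 8720 nM, the lowest of the three numbers known so far. Compound 2 `O=C(C1=C(Nc2ccccc2)C(=O)N(CCCn2ccnc2)C1c1ccc(Br)cc1)c1ccccc1` gives 24100 nM, and compound 3 `Cc1ccc(NC2=C(C(=O)c3ccccc3)C(c3ccc(Br)cc3)N(CCCn3ccnc3)C2=O)cc1` gives 29400 nM. Compound 4 `O=C(C1=C(Nc2ccc(I)cc2)C(=O)N(CCCn2ccnc2)C1c1ccc(Br)cc1)c1ccccc1` differs from compound 1 by (4-iodophenyl)amino in place of isopropoxy on a double-bonded ring carbon. Among the compounds with values here, two measured steps bear on this change: a 2.8-fold higher number from compound 1 to compound 2 (0.44 log units; beyond the scatter) and a 3.4-fold higher number from compound 1 to compound 3 (0.53 log units; beyond the scatter), both modest and both toward weaker inhibition. Between the two anilino compounds, a 1.2-fold higher number from compound 2 to compound 3 (0.09 log units; within the scatter), so the group on the aromatic ring mattered little there. A step of similar size toward a higher number is therefore expected, namely a 3.2-fold higher number from compound 1 to compound 4 (0.51 log units; beyond the scatter). Compound 4 is estimated at 28000 nM, with a range from 12000 nM to 70000 nM.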

Compound 4, half-maximal inhibitory concentration: 24500 nM
Compound 4: the middle estimate sits 1.1-fold (0.06 log units) above what was measured, and the stated range covers the measured number.
By their numbers in this assay, from the lowest: compound 1; then compounds 2, 4 and 3 (each within the scatter of the next).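

Iodo on the aromatic ring of the anilino group changes nothing beyond the scatter (a 1.0-fold higher number from compound 2 to compound 4 (0.01 log units; within the scatter); a 1.2-fold lower number from compound 3 to compound 4 (0.08 log units; within the scatter)), so hydrogen, methyl and iodo on that ring cannot be told apart here. The gap to isopropoxy remains (a 2.8-fold higher number from compound 1 to compound 4 (0.45 log units; beyond the scatter)), so in these compounds it follows the swap of isopropoxy for an aromatic amino group, not the group on that ring. No measurement at hand explains the size of these steps.

Still open, going by these compounds, is how methoxy or a plain amino group would read at this place, and whether a carboxylic acid on the aromatic ring would shift the number.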